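One Flipped Stereocentre, One Growth-Inhibition Number

The compounds below may be only part of what the source reports. "The series", "measured", "known", "first", "only" and "open" are said of these compounds alone.

Going by the values given here, in a functional assay on SNB-78 cells (Homo sapiens) for inhibition, read by sulforhodamine B assay, with a stated time of 48 h (on this read-out higher numbers stand for weaker inhibition of growth and lower numbers for stronger inhibition of growth), compound 2 `COc1ccc(C2([C@H]3C[C@H](n4cc(C)c(=O)[nH]c4=O)O[C@@H]3CO[Si](C)(C)C(C)(C)C)SCCCS2)cc1OC` gives 5500 nM, the only number available, while for compound 1 `Cc1cn([C@H]2C[C@H](CC3=CC(=O)C(=O)C=C3)[C@@H](CO[Si](C)(C)C(C)(C)C)O2)c(=O)[nH]c1=O` the entry reads no result reported. Compound 3 `COc1ccc(C2([C@H]3C[C@@H](n4cc(C)c(=O)[nH]c4=O)O[C@@H]3CO[Si](C)(C)C(C)(C)C)SCCCS2)cc1OC` has the same atoms and bonds as compound 2 and differs only in configuration as drawn: the two compounds have the same atoms and bonds and differ only in configuration as drawn: 1 of 3 stereo elements differ; a stereocentre at a saturated ring carbon is drawn R in compound 2 and S in compound 3. A stereocentre at a saturated ring carbon is drawn R in compound 2 and S in compound 3. Among the compounds with values here, no measured pair shows what such a change does here, so no direction can be read from the data, and no shift beyond the scatter is expected. The expected step is a 1.1-fold higher number from compound 2 to compound 3 (0.04 log units; within the scatter). For compound 3 the estimated value is 6000 nM, with an expected range from 2000 nM to 20000 nM.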

Compound 3, concentration for 50% growth inhibition: 12900 nM
Compound 3: middle estimate off by 2.2-fold (0.33 log units), on the low side; low and high end bracket the measured number.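

In this assay, the stereocentre at this saturated ring carbon matters: a 2.3-fold higher number from compound 2 to compound 3 (0.37 log units; beyond the scatter), the first measured sign that the drawn configuration here changes growth inhibition, with R giving the lower number. The step can be tied to this single stereocentre alone: the fact that compounds 2 and 3 differ only in the configuration as drawn

The compounds shown leave open what flipping either of the other two stereo elements would do. They also leave open whether the R-to-S change would have a similar effect if an amine or a carboxylic acid were carried on the shared core.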